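Fluoro for methyl on the aryl urea of compound 1

The source may hold more compounds than are shown below. What is called first, only, known or untested is meant among the compounds shown, and "the series" means these compounds.

Compound 1 `Cc1ccc(NC(=O)Nc2cccc(CNc3nccnc3Cl)c2)cc1Cl` is measured in a functional assay on MGC-803 cells (Homo sapiens) for antiproliferative activity, read by MTT assay, with a stated time of 48 h (on this read-out lower numbers stand for stronger inhibition and higher numbers for weaker inhibition), at 17500 nM. Compound 2 `O=C(Nc1cccc(CNc2nccnc2Cl)c1)Nc1ccc(Cl)cc1Br` gives 7480 nM in this assay and compound 3 `O=C(Nc1cccc(CNc2nccnc2Cl)c1)Nc1ccc(Cl)cc1Cl` gives 6430 nM. On these three numbers compound 1 stands highest, with compound 2 nearest and compound 3 furthest.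

Compound 4 `O=C(Nc1cccc(CNc2nccnc2Cl)c1)Nc1ccc(F)c(Cl)c1` differs from compound 1 in one place: fluoro in place of methyl on an aromatic carbon. The chloro group of compound 1 is kept; only the methyl is exchanged for fluoro on the same ring.

The two steps that leave compound 1 both replace the whole aryl group on the amide-type nitrogen, a 2.3-fold lower number from compound 1 to compound 2 (0.37 log units; beyond the scatter) and a 2.7-fold lower number from compound 1 to compound 3 (0.43 log units; beyond the scatter), so they are modest and both lower the number. Within the data shown here, neither is the same change as the one to compound 4, which is a single-atom swap on a ring that is otherwise unchanged. Among the measured compounds shown here, the only single-atom swap among the measured steps, a 1.2-fold lower number from compound 2 to compound 3 (0.07 log units; within the scatter), stays within the scatter. For compound 4 the expected step from compound 1 is therefore small, a 1.5-fold lower number from compound 1 to compound 4 (0.16 log units; within the scatter), leaning toward a lower number but not clearly beyond the scatter. Compound 4 is estimated at 12000 nM in this assay, with a range from 5000 nM to 30000 nM.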

Compound 4, half-maximal inhibitory concentration: 5020 nM
For compound 4 the middle estimate is 2.4-fold (0.38 log units) above the measured one, within the range that was stated.
By their numbers in this assay, from the lowest: compounds 4, 3 and 2 (each within the scatter of the next); then compound 1.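

In this assay, among these compounds, fluoro in place of methyl, para to a large group and ortho to a chloro group that stays in place, gives a 3.5-fold lower number from compound 1 to compound 4 (0.54 log units; beyond the scatter), so a single-atom swap on this aryl ring can reach beyond the scatter, which the chloro-for-bromo swap among the earlier compounds did not. Compound 4 cannot be told apart from the other two aryl variants, since a 1.3-fold lower number from compound 3 to compound 4 (0.11 log units; within the scatter) and a 1.5-fold lower number from compound 2 to compound 4 (0.17 log units; within the scatter) both stay within the scatter; among these four compounds, compound 1, the only one with a methyl, stands apart, and 3-chloro-4-fluorophenyl, 2,4-dichlorophenyl and 2-bromo-4-chlorophenyl do not separate. Nothing among the available data bears on why the step from methyl to fluoro has this size.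

Still open, on these data alone, is how this position responds to groups other than methyl and fluoro, such as a methoxy, an amine or a carboxylic acid. The compounds shown also leave open whether the fluoro-for-methyl step keeps its size when the chloro group gives way to a hydroxyl or a nitrile.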